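The source may hold more compounds than are shown below. What is called first, only, known or untested is meant among the compounds shown, and "the series" means these compounds.

Measured so far in a functional assay on MKN-74 cells (Homo sapiens) for antiproliferative activity, with a stated time of 24 h; a lower number here means a stronger inhibitor, a higher number a weaker inhibitor:
compound 1 `NC(=O)c1c(NC(=O)c2ccccc2Cl)sc2c1CCN(Cc1ccc(Cl)cc1)C2` gives 18700 nM
compound 2 `NC(=O)c1c(NC(=O)c2ccccc2Cl)sc2c1CCN(C(=O)Nc1ccccc1Cl)C2` gives 16300 nM

Among the compounds with values here, compound 2 holds the lower of the two numbers in this assay, but its only neighbour is compound 1, and the step of a 1.1-fold lower number from compound 1 to compound 2 (0.06 log units; within the scatter) leaves the two within the scatter, so no order between them is claimed.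

Compound 3 `NC(=O)c1c(NC(=O)c2ccccc2Cl)sc2c1CCN(C(=S)Nc1c(Cl)cccc1Cl)C2` differs from compound 2 by a group of 11 heavy atoms (7 carbon, 1 nitrogen, 1 sulfur, 2 chlorine; one six-membered aromatic ring of carbon only) in place of a group of 10 heavy atoms (7 carbon, 1 nitrogen, 1 oxygen, 1 chlorine; one six-membered aromatic ring of carbon only), on an amine nitrogen in a ring. The exchange sits on the same amine nitrogen in the ring that was varied between compound 1 and compound 2, and that variation, a 1.1-fold lower number from compound 1 to compound 2 (0.06 log units; within the scatter), produced no shift beyond the scatter. Within the data shown here, no measured pair covers the change from oxygen to sulfur or the additional chlorine on the aromatic ring, so nothing in the data argues for a large move in either direction. The expectation for compound 3 in this assay is therefore a step of about a 1.1-fold lower number from compound 2 to compound 3 (0.04 log units; within the scatter), within the scatter. Compound 3 is estimated at 15000 nM, with a range of 5000 nM to 45000 nM.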

Compound 3, half-maximal inhibitory concentration: 4020 nM
The estimate for compound 3 lay 3.7-fold (0.57 log units) above the measured number; the measured number lies below the stated range.
By their numbers in this assay, from the lowest: compound 3; then compounds 2 and 1 (each within the scatter of the next).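

In this assay the amine nitrogen in the ring now responds to its substituent, with a 4.1-fold lower number from compound 2 to compound 3 (0.61 log units; beyond the scatter) and a 4.7-fold lower number from compound 1 to compound 3 (0.67 log units; beyond the scatter), whereas the earlier exchange gave only a 1.1-fold lower number from compound 1 to compound 2 (0.06 log units; within the scatter). Compound 3 differs from compound 2 by sulfur in place of oxygen and by an added chlorine on the aromatic ring, both in one exchange, so the compounds shown do not assign the step to either change. Nothing available here bears on the reason for the step.

Still open, going by these compounds, is how much of the step belongs to sulfur and how much to the added chlorine, a question that (2-chlorophenyl)thiocarbamoyl would address directly. Also open, on these data alone, is whether the step survives on this nitrogen with a plain phenyl carrying no chlorine, or with a longer chain in place of the aromatic ring.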